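The source may report more compounds than this note shows. Statements on the series, on what has been measured and on what is new or still open speak of the compounds shown alone.

Measured compounds:
compound 1, `Cn1ncc2c(NC(=O)NCc3cc(C(F)(F)F)nn3-c3cccc(C(F)(F)F)c3)cccc21` — 1.4 nM
compound 2, `Cn1ncc2c(NC(=O)NCc3cc(C(F)(F)F)nn3-c3ccc(F)c(F)c3)cccc21` — 4.9 nM

In an assay on CHO-K1 cells for antagonist activity at transient receptor potential cation channel subfamily V member 1 (Homo sapiens), read by FLIPR and calcium flux, with a stated time of 6 min (on this read-out lower numbers stand for stronger inhibition and higher numbers for weaker inhibition), compound 1 gives 1.4 nM and compound 2 gives 4.9 nM. Going by the values given here, compound 2 therefore holds the higher of the two numbers measured so far, with compound 1 as its only neighbour, a 3.5-fold higher number from compound 1 to compound 2 (0.54 log units; beyond the scatter).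

Compound 3, `Cc1ccc(-n2nc(C(F)(F)F)cc2CNC(=O)Nc2cccc3c2cnn3C)cc1C`, has not been measured in this assay. It differs from compound 2 in one place: 3,4-dimethylphenyl in place of 3,4-difluorophenyl on an aromatic nitrogen. Among the compounds with values here, the only step that bears on this change is the one between compound 1 and compound 2, a 3.5-fold higher number from compound 1 to compound 2 (0.54 log units; beyond the scatter), which shows that exchanging the aryl group on the aromatic nitrogen moves the number by a modest amount, beyond the scatter but not by much. Within the data shown here, no measured compound carries a dimethyl-substituted ring at this position, so the direction of the step is not fixed by the data.

Given the modest size of the one relevant step, compound 3 is expected to stay close to compound 2, with a step of a 1.4-fold lower number from compound 2 to compound 3 (0.15 log units; within the scatter) as the central guess. The estimate for compound 3 in this assay is 3.5 nM, with a range from 1 nM to 12 nM.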

Compound 3, inhibition constant: 3.5 nM
Estimate against measurement, compound 3: no gap at the digits printed; low and high end bracket the measured number.
By their numbers in this assay, from the lowest: compound 1; then compounds 3 and 2 (each within the scatter of the next).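

In this assay, the exchange of 3,4-difluorophenyl for 3,4-dimethylphenyl on the aromatic nitrogen gives a 1.4-fold lower number from compound 2 to compound 3 (0.15 log units; within the scatter), so this read-out does not separate these two rings, although one carries fluorine and the other carbon substituents. The 3-(trifluoromethyl)phenyl ring of compound 1 now stands apart from both disubstituted rings, with a 2.5-fold higher number from compound 1 to compound 3 (0.40 log units; beyond the scatter) alongside a 3.5-fold higher number from compound 1 to compound 2 (0.54 log units; beyond the scatter), which makes compound 1 the strongest of the three and shows that the earlier step was not specific to the difluoro ring. Nothing available here explains either step or the match between compound 2 and compound 3.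

On these data alone, all three compounds carry a phenyl ring with only fluorine, methyl or trifluoromethyl substituents at this position, so it remains open whether the advantage of compound 1 lies with the trifluoromethyl group itself or with the ring carrying a single substituent. As far as these compounds go, the response of the number to a ring bearing an amine or a carboxylic acid, or to a saturated cyclohexyl group in place of the phenyl ring, also remains open.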